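Replacing the 4-fluorophenyl group on the amide nitrogen

The source may report more compounds than this note shows. Statements on the series, on what has been measured and on what is new or still open speak of the compounds shown alone.

In a functional assay on MDA-MB-231 cells (Homo sapiens) for inhibition, read by MTT assay (on this read-out higher numbers stand for weaker inhibition of growth and lower numbers for stronger inhibition of growth), compound 1 `CC1=C(/C=C/C(C)=C/C=C/C(C)=C\C(=O)Nc2ccccc2)C(C)(C)CCC1n1ccnc1` gives 1740 nM, while compound 2 `CC1=C(/C=C/C(C)=C/C=C/C(C)=C\C(=O)Nc2ccc(F)cc2)C(C)(C)CCC1n1ccnc1` gives 4950 nM, the higher of the two numbers and so the weaker inhibition of growth. Compound 3 `CC1=C(/C=C/C(C)=C/C=C/C(C)=C\C(=O)Nc2ccccc2O)C(C)(C)CCC1n1ccnc1` has not yet been measured. It keeps the shared core of compound 2 and changes one group on an amide-type nitrogen: 2-hydroxyphenyl in place of 4-fluorophenyl on an amide-type nitrogen. Going by the values given here, only one measured step bears on this change: a 2.8-fold higher number from compound 1 to compound 2 (0.45 log units; beyond the scatter), which comes from fluoro in place of hydrogen on an aromatic carbon and is modest but beyond the scatter. Compound 3 carries no fluoro, and neither does compound 1 at 1740 nM, so some return towards lower numbers seems likely. Among the compounds with values here, no measured compound shows what the 2-hydroxyphenyl group itself does, which leaves the expectation loose. A modest change in this assay towards stronger inhibition is expected, with the estimate being a 2.2-fold lower number from compound 2 to compound 3 (0.33 log units; beyond the scatter). The estimated value for compound 3 is 2300 nM, with an expected range of 800 nM to 6000 nM.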

Compound 3, concentration for 50% growth inhibition: 4670 nM
The estimate for compound 3 lay 2.0-fold (0.31 log units) below the measured number, and the stated range covers the measured number.
By their numbers in this assay, from the lowest: compound 1; then compounds 3 and 2 (each within the scatter of the next).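

In this assay, putting 2-hydroxyphenyl in place of 4-fluorophenyl on the amide-type nitrogen gives a 1.1-fold lower number from compound 2 to compound 3 (0.03 log units; within the scatter), so this assay does not separate the two groups, even though 2-hydroxyphenyl brings a hydrogen-bond donor and acceptor that 4-fluorophenyl lacks. Losing the fluoro therefore brought no return towards compound 1: the hydroxy group gives a 2.7-fold higher number from compound 1 to compound 3 (0.43 log units; beyond the scatter), much like the fluoro group's a 2.8-fold higher number from compound 1 to compound 2 (0.45 log units; beyond the scatter), which leaves compound 1, carrying neither group, with the lowest number of the three. Nothing available explains why these two different changes end up alike.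

Fluoro and hydroxy differ in kind and also sit at different places, as the names 4-fluorophenyl and 2-hydroxyphenyl show, so the compounds shown cannot separate the effect of the group from the effect of its place. They also leave open how an amine or a carboxylic acid on that aromatic ring would read in this assay, and what a plain alkyl chain would do in place of the aromatic group on the amide-type nitrogen.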